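This account rests on a few compounds, and the source may have more. Where it says the series, first, only, none or still open, it means among the compounds named here.

Compound 3 `CC1=NC(c2cn(S(=O)(=O)c3ccccc3C)c3ccc(C)cc23)CN1` stands lowest of the two numbers in an assay on isolated protein for inhibition of kallikrein-7 (Mus musculus), read by fluorescence, with stated times of 10 min and 30 min (on this read-out lower numbers stand for stronger inhibition and higher numbers for weaker inhibition), with 1300 nM. The nearest value belongs to compound 1 `CC1=NC(c2cn(S(=O)(=O)c3ccccc3)c3ccc(C)cc23)CN1`, which gives 15000 nM; the step is a 12-fold lower number from compound 1 to compound 3 (1.06 log units; beyond the scatter). Compound 2 `CC1=NC(c2cn(S(=O)(=O)c3ccc(F)cc3)c3ccc(C)cc23)CN1` gives in this assay only a limit, > 30000 nM. That limit is the limit of > 30000 nM in this assay, at which 1 of the 3 values shown sits. From compound 1 to compound 2 the step reads an at least 2.0-fold higher number from compound 1 to compound 2 (0.30 log units; that floor lies within the scatter), and from compound 2 to compound 3 it reads an at least 23-fold lower number from compound 2 to compound 3 (1.36 log units; beyond the scatter).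

Compound 4 `CC1=NC(c2cn(S(=O)(=O)c3ccccc3Br)c3ccc(C)cc23)CN1` differs from compound 3 by bromo in place of methyl on an aromatic carbon. Within the data shown here, no measured step swaps a methyl for a bromo; the only step that bears on this position is the methyl in place of hydrogen from compound 1 to compound 3, a 12-fold lower number from compound 1 to compound 3 (1.06 log units; beyond the scatter), which was large. The fluoro in place of hydrogen elsewhere on the same ring gave a higher number, an at least 2.0-fold higher number from compound 1 to compound 2 (0.30 log units; that floor lies within the scatter), but at a floor inside the scatter. Since a substituent remains at the position that carried the methyl, the expected step in this assay from compound 3 to compound 4 is a 1.2-fold higher number from compound 3 to compound 4 (0.06 log units; within the scatter), likely none beyond the scatter. Compound 4 is therefore estimated at 1500 nM in this assay, with a range from 500 nM to 5000 nM.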

Compound 4, half-maximal inhibitory concentration: 400 nM
For compound 4 the middle estimate is 3.8-fold (0.57 log units) above the measured one; the measured number lies below the stated range.
By their numbers in this assay, from the lowest: compound 4; then compound 3; then compound 1. At a limit, above all of these: compound 2.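

In this assay, the gain at this position, on an aromatic carbon ortho to a large group, is not tied to the methyl: the change to bromo reads a 3.3-fold lower number from compound 3 to compound 4 (0.51 log units; beyond the scatter), so a second substituent here gives a lower number, and the step lies beyond the scatter. Measured against hydrogen at the same place, bromo gives a 38-fold lower number from compound 1 to compound 4 (1.57 log units; beyond the scatter), which goes further than methyl with a 12-fold lower number from compound 1 to compound 3 (1.06 log units; beyond the scatter), so the series now reads hydrogen, then methyl, then bromo on this carbon, from the highest number to the lowest. The change of the whole group, 2-bromophenyl in place of 4-fluorophenyl, reads an at least 75-fold lower number from compound 2 to compound 4 (1.87 log units; beyond the scatter), and that step is only a floor, as it rests on a limit: the limit of > 30000 nM in this assay, at which 1 of the 4 values shown sits.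

With only hydrogen, methyl and bromo at this position, the compounds shown cannot say how chloro, methoxy, trifluoromethyl or an amine would read there, nor what sets the order of the three. They also leave open whether the bromo step holds when the methyl elsewhere on the shared core is replaced by another group, such as a carboxylic acid.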